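The compounds below may be only part of what the source reports. "The series", "measured", "known", "first", "only" and "open" are said of these compounds alone.

Values in a functional assay on K562 cells (Homo sapiens) for cytotoxicity, read by MTT assay, with a stated time of 48 h; a lower number here means a stronger inhibitor, a higher number a weaker inhibitor
Compound 1 `Cc1ccccc1CN1CCN(C(=O)CN[C@H]2CCN(S(=O)(=O)Cc3ccccc3)C2)CC1` gives 10200 nM
Compound 2 `O=C(CN[C@H]1CCN(S(=O)(=O)Cc2ccccc2)C1)N1CCN(Cc2cccc(F)c2)CC1` gives 13200 nM

Compound 2 stands level with compound 1 within the scatter. Compound 3 `O=C(CN[C@H]1CCN(S(=O)(=O)Cc2ccccc2)C1)N1CCN(Cc2cccc(C(F)(F)F)c2)CC1` carries trifluoromethyl in place of fluoro on an aromatic carbon. Among the measured compounds shown here, the only measured step (a 1.3-fold higher number from compound 1 to compound 2 (0.11 log units; within the scatter)) also changes the substituent on this aromatic ring and lies within the scatter, but it involves a different swap and is only a loose guide. In this assay no step beyond the scatter is therefore expected, the estimated step being (a 1.3-fold lower number from compound 2 to compound 3 (0.12 log units; within the scatter)). Compound 3 is estimated at 10000 nM (expected range 5000 nM to 20000 nM).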

Compound 3, half-maximal inhibitory concentration: 3600 nM
Compound 3: middle estimate off by 2.8-fold (0.44 log units), on the high side, and the stated range ends above it.
By their numbers in this assay, from the lowest: compound 3; then compounds 1 and 2 (each within the scatter of the next).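

In this assay, among the compounds shown here, trifluoromethyl in place of fluoro on this aromatic carbon gives a 3.7-fold lower number from compound 2 to compound 3 (0.56 log units; beyond the scatter), the first step beyond the scatter, so the substituent on this ring can shift the number. Moving from the 2-methylphenyl group to 3-(trifluoromethyl)phenyl gives a 2.8-fold lower number from compound 1 to compound 3 (0.45 log units; beyond the scatter), also beyond the scatter. Nothing available bears on the reason for either step.

Going by these compounds, whether this shift is specific to trifluoromethyl remains open. Chloro, methoxy or nitrile on the same carbon would help to settle that, as would trifluoromethyl on another carbon of the ring.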